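This account rests on a few compounds, and the source may have more. Where it says the series, first, only, none or still open, it means among the compounds named here.

Measured compounds in the series:
compound 1, `COc1ccc(-c2cn(Cc3ccc(F)cc3)c(=O)c(C(=O)NC3CCCCCC3)c2C)cc1`, 1300 nM
compound 2, `O=C(NC1CCCCCC1)c1c(-c2ccccc2)c(Br)cn(Cc2ccc(F)cc2)c1=O`, > 10000 nM
compound 3, `COc1ccc(-c2c(Br)cn(Cc3ccc(F)cc3)c(=O)c2C(=O)NC2CCCCCC2)cc1`, > 10000 nM

Among the measured compounds shown here, in an ADME assay on cells for inhibition of Fatty-acid amide hydrolase 1 (Homo sapiens), with stated times of 30 min and 15 min (on this read-out higher numbers stand for weaker inhibition and lower numbers for stronger inhibition), compound 1 gives 1300 nM, the only numeric value among the three. For compound 2 the read-out is a limit of the assay, > 10000 nM. For compound 3 the read-out is likewise a limit of the assay, > 10000 nM. The change from compound 3 to compound 2 is hydrogen in place of methoxy on an aromatic carbon; its step in this assay, a step that the two limits leave unreadable from compound 3 to compound 2, cannot be read because the limit of > 10000 nM in this assay, at which 2 of the 3 values shown sit, covers both values. How the core of compound 1 differs from that of compound 3 is not broken down here.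

Compound 4, `Cc1c(-c2ccccc2)cn(Cc2ccc(F)cc2)c(=O)c1C(=O)NC1CCCCCC1`, is not yet measured. It differs from compound 1 by hydrogen in place of methoxy on an aromatic carbon, the same kind of change as from compound 3 to compound 2, at a place described in the same words. With the measured example of this change unreadable, no size can be taken over from it. The step from compound 1 to compound 4 in this assay is therefore estimated only loosely, as a 2.3-fold higher number from compound 1 to compound 4 (0.36 log units; beyond the scatter). Compound 4 is expected to give 3000 nM, with a range from 800 nM to 12000 nM.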

Compound 4, half-maximal inhibitory concentration: 70 nM
For compound 4 the middle estimate is 43-fold (1.63 log units) above the measured one; the measured number lies below the stated range.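

In this assay, the change 4-methoxyphenyl to phenyl on the core of compound 1 gives a 19-fold lower number from compound 1 to compound 4 (1.27 log units; beyond the scatter), a large step in favour of the phenyl compound. The same change on the core of compound 3 cannot be read, because compound 3 and compound 2 both sit at a limit of the assay: the limit of > 10000 nM in this assay, at which 2 of the 4 values shown sit. This leaves one readable example of the change, on a single core, so the series neither shows nor rules out that a step of this size carries over from one core to the other.

The compounds shown leave open whether an amine, a hydroxyl or a carboxylic acid in place of the hydrogen para to a large group would keep the number of compound 4, 70 nM. Also open, on these data alone, is how a chlorine or an ethyl group would behave at the core position held by methyl in compound 4 and by bromine in compound 2.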